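The source may hold more compounds than are shown below. What is called first, only, known or untested is meant among the compounds shown, and "the series" means these compounds.

Among the compounds with values here, compound 1 `C=CCn1c(=O)/c(=C\c2ccccc2Cl)[nH]c(=O)/c1=C\c1ccccc1OC` is the weaker of the two compounds measured so far: in a functional assay on BGC-823 cells (Homo sapiens) for cytotoxicity, read by CCK-8 assay, with a stated time of 72 h (a lower number here means a stronger inhibitor, a higher number a weaker inhibitor), compound 1 gives 4600 nM, while compound 2 `COc1ccccc1/C=c1\c(=O)[nH]/c(=C/c2ccccc2Cl)c(=O)n1C` gives 300 nM. Within the data shown here, the only step measured between them, a 15-fold lower number from compound 1 to compound 2 (1.19 log units; beyond the scatter), concerns the chain on the ring nitrogen and not the halogen.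

Compound 3 `C=CCn1c(=O)/c(=C\c2ccccc2F)[nH]c(=O)/c1=C\c1ccccc1OC` differs from compound 1 in one place: fluoro in place of chloro on an aromatic carbon. Among the measured compounds shown here, no measured pair shows what this swap of one halogen for another does in this assay, so there is nothing to say which way the number should move. The expected step is therefore small, a 1.1-fold higher number from compound 1 to compound 3 (0.04 log units; within the scatter), lying within the usual scatter of repeated measurements. Compound 3 is thus estimated to give about 5000 nM in this assay, with a range from 1800 nM to 14000 nM allowing for the unknown effect of the change.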

Compound 3, half-maximal inhibitory concentration: 18900 nM
Compound 3: the middle estimate sits 3.8-fold (0.58 log units) below what was measured; the whole stated range lies below it.
By their numbers in this assay, from the lowest: compound 2; then compound 1; then compound 3.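

Swapping one halogen for another on this aromatic carbon is not a neutral change: going from 2-chlorophenyl to 2-fluorophenyl in this assay gives a step beyond the scatter (a 4.1-fold higher number from compound 1 to compound 3 (0.61 log units; beyond the scatter)), and the chloro compound is the stronger of the pair. Until now, only the chain on the ring nitrogen had been shown to matter (a 15-fold lower number from compound 1 to compound 2 (1.19 log units; beyond the scatter)), whereas this pair shows that the halogen also affects the result, though its step is modest and the nitrogen step large. Nothing available gives a reason for the loss with fluoro.

From the compounds shown here alone, it remains open whether bromo or methyl in the place of chloro would give a lower or a higher number. Going by these compounds, it is also open whether the same swap to fluoro would produce a similar step in compound 2, which carries the smaller group on the ring nitrogen.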